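Diethylamino for cyclobutyl on a sulfonyl sulfur

The source may report more compounds than this note shows. Statements on the series, on what has been measured and on what is new or still open speak of the compounds shown alone.

In a functional assay on MIA PaCa-2 cells (Homo sapiens) for inhibition, read by MTT assay, with a stated time of 3 days (on this read-out higher numbers stand for weaker inhibition and lower numbers for stronger inhibition), compound 3 (`CC(C)c1noc(N2CCN(C(=O)[C@@H]3CCCN(S(=O)(=O)c4ccc(S(=O)(=O)C5CCC5)cc4)C3)CC2)n1`) gives > 10000 nM and this is a limit, not a number. Compound 1 (`CCN(CC)S(=O)(=O)c1ccc(S(=O)(=O)N2CCC[C@@H](C(=O)NC)C2)cc1`) gives > 10000 nM and this is also a limit. Compound 2 (`CCN(CC)S(=O)(=O)c1ccc(S(=O)(=O)N2CCC[C@@H](C(=O)NC3CN(C(=O)OC(C)(C)C)C3)C2)cc1`) gives > 10000 nM and this too is a limit. The whole set rests on the limit of > 10000 nM in this assay, at which 3 of the 3 values shown sit, and holds no measured number.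

Compound 4 (`CCN(CC)S(=O)(=O)c1ccc(S(=O)(=O)N2CCC[C@@H](C(=O)N3CCN(c4nc(C(C)C)no4)CC3)C2)cc1`) keeps the amide part of compound 3 and takes the diethylsulfamoyl group found in compound 1 and compound 2. The change is diethylamino in place of cyclobutyl on a sulfonyl sulfur and it puts diethylamino in place of cyclobutyl on a sulfonyl sulfur.

Going by the values given here, the only measured step is a step that the two limits leave unreadable from compound 1 to compound 2 and it lies on an amide-type nitrogen, so it gives neither a size nor a direction for this change. A further limit in this assay is the likeliest expected outcome, though a measurable number cannot be excluded. The estimated move is an at least 1.2-fold lower number from compound 3 to compound 4 (0.09 log units; that floor lies within the scatter) and its size is highly uncertain. For compound 4 the estimate is 8000 nM with an expected range of 500 nM to 20000 nM on this assay.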

Compound 4, half-maximal inhibitory concentration: > 10000 nM
Compound 4: no number, only a limit; the forecaster's own chance of this, stated with the estimate: 60%; middle value at least 1.2-fold (0.09 log units) from the limit.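

In this assay compound 4 gives > 10000 nM, which is a limit and not a number, so the change from compound 3 to compound 4 cannot be read as a step. The compounds shown leave open which change, if any, would give a measurable number: the limit of > 10000 nM in this assay, at which 4 of the 4 values shown sit.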